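A Methyl Added to the Boronic Acid Compound

The source may report more compounds than this note shows. Statements on the series, on what has been measured and on what is new or still open speak of the compounds shown alone.

Compound 1 `CCONC(=O)c1cccc2c1cc(C)n2-c1nc2c(c(NCc3cccc(O)c3)n1)CCC2` gives 600 nM
Compound 2 `CONC(=O)c1cccc2c1cc(C)n2-c1nc2c(c(NCc3cccc(B(O)O)c3)n1)CCC2` gives 1000 nM

Among the measured compounds shown here, in a functional assay on HCT-116 cells (Homo sapiens) for inhibition, read by luminescence and CellTiter-Glo, with a stated time of 72 h (a higher number here means a weaker inhibitor, a lower number a stronger inhibitor), compound 2 gives 1000 nM and so stands within the usual scatter of compound 1, the only other compound measured so far. The next compound changes one small detail. Methyl takes the place of hydrogen on a saturated chain carbon bound to an oxygen on an unsaturated carbon, so methoxyamino becomes ethoxyamino (methyl in place of hydrogen on a saturated chain carbon bound to an oxygen on an unsaturated carbon) in compound 3 `CCONC(=O)c1cccc2c1cc(C)n2-c1nc2c(c(NCc3cccc(B(O)O)c3)n1)CCC2` while the rest of compound 2 stays the same. For the measured compounds named here, no measured pair shows this change on its own, so the data give no direct size for it. Only a modest effect is expected, with no shift beyond the scatter in either direction. The estimated change is a 1.3-fold lower number from compound 2 to compound 3 (0.10 log units; within the scatter) and stays within the scatter. In this assay compound 3 is expected at 800 nM with an estimated range from 300 nM to 2000 nM for repeat measurements.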

Compound 3, half-maximal inhibitory concentration: 1400 nM
Estimate against measurement, compound 3: 1.8-fold (0.24 log units) below; low and high end bracket the measured number.
By their numbers in this assay, from the lowest: compounds 1, 2 and 3 (each within the scatter of the next, the first and the last beyond it).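

In this assay the change from methoxyamino to ethoxyamino on the boronic acid compound gives a 1.4-fold higher number from compound 2 to compound 3 (0.15 log units; within the scatter), so this added methyl does not clearly separate the two compounds. With ethoxyamino now on both sides, the hydroxyl compound and the boronic acid compound differ in one place, on an aromatic carbon, and that swap gives a 2.3-fold higher number from compound 1 to compound 3 (0.37 log units; beyond the scatter), a modest step and the only one here beyond the scatter. Nothing available explains the size of either step.

Still open, from the compounds shown here alone, is how a longer chain, such as propoxyamino, would behave on this saturated chain carbon. Also open, going by these compounds, is how an amine or a carboxylic acid would compare on that aromatic carbon.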